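The source may report more compounds than this note shows. Statements on the series, on what has been measured and on what is new or still open speak of the compounds shown alone.

Compounds with numbers in hand:

Compound 1, `COc1ccc(C(=O)/C=C/c2ccccc2-c2ccc(F)cc2)cc1`, gives 8400 nM in a functional assay on SW480 cells (Homo sapiens) for antiproliferative activity, read by sulforhodamine B assay, with a stated time of 48 h; on this read-out higher numbers stand for weaker inhibition and lower numbers for stronger inhibition.
Compound 2, `COc1ccc(C(=O)/C=C/c2ccccc2-c2ccc(F)nc2)cc1`, gives 10000 nM in this assay.
Compound 3, `COc1ccc(C(=O)/C=C/c2ccccc2-c2ccc(F)nc2)cc1OC`, gives 15000 nM in this assay.

Compound 2 sits second highest of the three numbers; its nearest neighbour is compound 1, its furthest compound 3, and both gaps are within the scatter. Going by the values given here, the two steps that connect the measured compounds, a 1.2-fold higher number from compound 1 to compound 2 (0.08 log units; within the scatter) and a 1.5-fold higher number from compound 2 to compound 3 (0.18 log units; within the scatter), are both small: the first swaps the aryl group on the shared core, the second adds a methoxy group, and neither moves the number beyond the scatter.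

The next compound, compound 4, `O=C(/C=C/c1ccccc1-c1ccc(F)nc1)c1cccc(O)c1`, differs from compound 2 at the carbonyl side of the core: 3-hydroxyphenyl in place of 4-methoxyphenyl on a carbonyl carbon. Among the compounds with values here, no measured step touches this part of the molecule, so the evidence bearing on it is only indirect. The closest analogy is the step from compound 2 to compound 3, which changed the oxygen substitution on the same ring and stayed within the scatter. Compound 4 is therefore expected to give a number close to that of compound 2, with the step of a 1.2-fold higher number from compound 2 to compound 4 (0.08 log units; within the scatter) not beyond the scatter. Compound 4 is estimated at 12000 nM in this assay, within a range of 5000 nM to 30000 nM.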

Compound 4, half-maximal inhibitory concentration: 7400 nM
Compound 4: middle estimate off by 1.6-fold (0.21 log units), on the high side, within the range that was stated.
By their numbers in this assay, from the lowest: compounds 4, 1, 2 and 3 (each within the scatter of the next, the first and the last beyond it).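

Going by these compounds alone, compound 4 brings the first change to the whole group on the carbonyl carbon, where the earlier steps had only altered the aryl group on the other side of the shared core or added a methoxy group. In this assay, exchanging 4-methoxyphenyl for 3-hydroxyphenyl gives a 1.4-fold lower number from compound 2 to compound 4 (0.13 log units; within the scatter), so this position accepts a group carrying a hydrogen-bond donor, which the departing group lacks, without a change beyond the scatter. No available evidence bears on what lies behind this result.

The single exchange replaces methoxy with hydroxyl and also alters the substitution pattern on the ring, so the compounds shown leave open whether either change matters on its own, or whether the two offset each other. Within the data shown here, they also leave open whether an amine or a carboxylic acid in place of the hydroxyl on the 3-hydroxyphenyl group would likewise stay within the scatter of compound 4, or would instead produce the first step in this set that moves beyond it.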